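From isobutyl to pentyl: one small change

This account rests on a few compounds, and the source may have more. Where it says the series, first, only, none or still open, it means among the compounds named here.

compound 1 `NC(=O)CC[C@H](NS(=O)(=O)c1ccc([N+](=O)[O-])cc1)C(=O)O`: > 500000 nM
compound 2 `CNC(=O)CC[C@H](NS(=O)(=O)c1ccc([N+](=O)[O-])cc1)C(=O)O`: > 500000 nM
compound 3 `CC(C)CNC(=O)CC[C@H](NS(=O)(=O)c1ccc([N+](=O)[O-])cc1)C(=O)O`: 42500 nM

These values come from a functional assay on K562 cells (Homo sapiens) for cytotoxicity, read by MTT assay, with a stated time of 48 h; on this read-out higher numbers stand for weaker inhibition and lower numbers for stronger inhibition. The entries for compound 1 and compound 2 are limits and not numbers, as the limit of > 500000 nM in this assay, at which 2 of the 3 values shown sit, makes clear. For the measured compounds named here, compound 3, at 42500 nM, holds the only true number so far.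

Compound 4 `CCCCCNC(=O)CC[C@H](NS(=O)(=O)c1ccc([N+](=O)[O-])cc1)C(=O)O` differs from it in one place: butyl in place of isopropyl on a saturated chain carbon bound to an amide-type nitrogen. Put simply, the change turns isobutyl into pentyl.

Going by the values given here, two measured steps bear on this change: an at least 11-fold lower number from compound 1 to compound 3 (1.07 log units; beyond the scatter) and an at least 11-fold lower number from compound 2 to compound 3 (1.07 log units; beyond the scatter). Both are large, and both lead to a lower number as a bigger group appears on the amide-type nitrogen. Each starts from a limit, however, and neither compares two chains of similar size. The present change is far smaller, so only a modest shift in the same direction is expected in this assay, possibly no more than the usual scatter. The expected step is a 1.5-fold lower number from compound 3 to compound 4 (0.18 log units; within the scatter). Compound 4 is estimated at 28000 nM, with an expected range from 10000 nM to 70000 nM.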

Compound 4, half-maximal inhibitory concentration: 17900 nM
The estimate for compound 4 lay 1.6-fold (0.19 log units) above the measured number; low and high end bracket the measured number.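

In this assay, the change from isobutyl to pentyl gives a 2.4-fold lower number from compound 3 to compound 4 (0.38 log units; beyond the scatter), the only step shown that joins two true numbers rather than a limit and a number. It shows that even a change as small as butyl in place of isopropyl, on a saturated chain carbon bound to an amide-type nitrogen, can reach beyond the usual scatter, so the exact shape and length of this chain matter here and not merely the presence of a larger group. Set against the two compounds with smaller groups on that nitrogen, pentyl gives an at least 27-fold lower number from compound 2 to compound 4 (1.44 log units; beyond the scatter) and an at least 27-fold lower number from compound 1 to compound 4 (1.44 log units; beyond the scatter), and each of these steps starts from a limit and not from a number: the limit of > 500000 nM in this assay, at which 2 of the 4 values shown sit.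

Isobutyl and pentyl differ in both branching and length, so an unbranched butyl chain or an isopentyl chain on the same nitrogen would be needed to tell those two apart. As far as these compounds go, whether the number keeps falling with a longer chain such as octyl, or with a ring-bearing group such as benzyl, also remains open.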